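Sulfonyl for sulfanyl, repeated in a second pair

The source may report more compounds than this note shows. Statements on the series, on what has been measured and on what is new or still open speak of the compounds shown alone.

Of the compounds shown here, three have been measured in a functional assay on DU-145 cells (Homo sapiens) for antiproliferative activity, read by fluorescence and propidium iodide staining, with a stated time of 96 h; on this read-out higher numbers stand for weaker inhibition and lower numbers for stronger inhibition. Compound 1 `O=C(Nc1ccc([N+](=O)[O-])c(C(F)(F)F)c1)c1ccc(Sc2ccc(O)cc2)cc1` gives 5740 nM. Compound 3 `O=C(Nc1ccc([N+](=O)[O-])c(C(F)(F)F)c1)c1ccc(S(=O)(=O)c2ccc(O)cc2)cc1` differs from it by (4-hydroxyphenyl)sulfonyl in place of (4-hydroxyphenyl)sulfanyl on an aromatic carbon and gives 8850 nM; the step of a 1.5-fold higher number from compound 1 to compound 3 (0.19 log units; within the scatter) is reported as within the scatter. Compound 2 `O=C(Nc1cc(C(F)(F)F)cc(C(F)(F)F)c1)c1ccc(Sc2ccc(O)cc2)cc1` gives 5600 nM; the difference between the core of compound 2 and the core of compound 1 is not broken down here, and the values of compound 1 and compound 2 lie within the scatter of each other, as do those of compound 2 and compound 3.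

Compound 4 `O=C(Nc1cc(C(F)(F)F)cc(C(F)(F)F)c1)c1ccc(S(=O)(=O)c2ccc(O)cc2)cc1` has not yet been measured. Relative to compound 2 it carries (4-hydroxyphenyl)sulfonyl in place of (4-hydroxyphenyl)sulfanyl on an aromatic carbon, the same change that separates compound 3 from compound 1, at a place described in the same words. Because the earlier step of a 1.5-fold higher number from compound 1 to compound 3 (0.19 log units; within the scatter) stayed within the scatter, the step from compound 2 to compound 4 in this assay is expected to be of similar size, a 1.5-fold higher number from compound 2 to compound 4 (0.18 log units; within the scatter). Compound 4 is accordingly estimated at 8500 nM in this assay, with a likely range from 4200 nM to 17000 nM.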

Compound 4, half-maximal inhibitory concentration: 9920 nM
Beside the measured number, compound 4's estimate is 1.2-fold (0.07 log units) below it, within the range that was stated.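

In this assay, the exchange of (4-hydroxyphenyl)sulfanyl for (4-hydroxyphenyl)sulfonyl on the second core gives a 1.8-fold higher number from compound 2 to compound 4 (0.25 log units; within the scatter). Set beside the earlier pair, the change reads alike on the two cores: the same change on two cores in this assay, a 1.5-fold higher number (0.19 log units; within the scatter) from compound 1 to compound 3 and a 1.8-fold higher number (0.25 log units; within the scatter) from compound 2 to compound 4, 1.1-fold (0.06 log units) apart, within the scatter of two such steps. This shows that, across these two pairs, the exchange carries from one core to the other with no difference that can be told apart, but each step on its own lies within the scatter, so the pairs do not establish a real loss of inhibition on either core, and they say nothing about cores beyond these two.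

As far as these compounds go, it remains open how these values would stand with a sulfinyl group or an ether oxygen in place of the sulfur, or with an amine or a carboxylic acid in place of the hydroxyl. Also open, from the compounds shown here alone, is whether the exchange would read the same on a core carrying a nitrile or a chlorine.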